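Swapping the Aryl Group on a Piperazine Chain

The compounds below may be only part of what the source reports. "The series", "measured", "known", "first", "only" and "open" are said of these compounds alone.

Of the compounds shown here, two have been measured in an assay on HEK293 cells for displacement of a labelled ligand from 5-hydroxytryptamine receptor 7 (Rattus norvegicus); a higher number here means a weaker inhibitor, a lower number a stronger inhibitor. Compound 1 `COc1ccccc1N1CCN(CC(=O)NC2CCCc3c(OC)cccc32)CC1` reports only a limit of the assay, > 1000 nM. Compound 2 `COc1ccc2oc(N3CCN(CCCCCC(=O)NC4CCCc5ccccc54)CC3)nc2c1` gives 704 nM in this assay. Within the data shown here, compound 2 therefore stands as the only measured number in the set, the other value being a limit: the limit of > 1000 nM in this assay, at which 1 of the 2 values shown sits. Compound 3 `CC(=O)c1cccc(N2CCN(CCCCCC(=O)NC3CCCc4ccccc43)CC2)c1` has not yet been measured. It differs from compound 2 at a single place: 3-acetylphenyl in place of 5-methoxy-1,3-benzoxazol-2-yl on an amine nitrogen in a ring, with the rest of the molecule, the linking chain and the amide, kept unchanged. Among the measured compounds shown here, no measured pair shows an exchange of this kind, so the size of the step rests on expectation alone. The expected step of a 1.7-fold higher number from compound 2 to compound 3 (0.23 log units; within the scatter) is a modest weakening, beyond the usual scatter but not a large one. For compound 3 the estimated value in this assay is 1200 nM, with a range from 350 nM to 4000 nM, and a fair chance that only a limit is reported.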

Compound 3, inhibition constant: 496 nM
The estimate for compound 3 lay 2.4-fold (0.38 log units) above the measured number; measured number inside the range.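

Among these compounds, this exchange provides the only measured step at this place, on an amine nitrogen in a ring, and in this assay it gives a 1.4-fold lower number from compound 2 to compound 3 (0.15 log units; within the scatter). The group that leaves has two aromatic rings, 11 heavy atoms and 3 hydrogen-bond acceptors, while the group that enters has one aromatic ring, 9 heavy atoms and 1 hydrogen-bond acceptor, so on this linking chain a large change in the group comes with no difference beyond the usual scatter: the benzoxazole ring system is not required for a measured number of this size, and a single substituted benzene ring serves as well. Among the compounds shown here, nothing measured so far explains why these two different groups give values so close together.

From the compounds shown here alone, it remains open whether the acetyl group contributes at all, which a plain phenyl group, or a phenyl group carrying an amine or a carboxylic acid in its place, would test. Going by these compounds, it is also open whether the 3-acetylphenyl group would give a similar value on a shorter or a longer chain.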